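The source may hold more compounds than are shown below. What is called first, only, known or untested is meant among the compounds shown, and "the series" means these compounds.

Compound 2 `Cc1ncc([N+](=O)[O-])n1CC(O)CSC(=S)N1CCN(c2cccc(Cl)c2Cl)CC1` and compound 1 `CCN1CCN(C(=S)SCC(O)Cn2c([N+](=O)[O-])cnc2C)CC1` share a core and differ in one place: ethyl in place of 2,3-dichlorophenyl on an amine nitrogen in a ring. In a toxicity assay on HeLa cells (Homo sapiens) for cytotoxicity, read by MTT assay, with a stated time of 24 h (a lower number here means a stronger inhibitor, a higher number a weaker inhibitor), compound 2 gives 1000000 nM. Compound 1 reaches only a limit of the assay in this assay, > 5000000 nM, so no number is known for it. The step from the one to the other is therefore an at least 5.0-fold higher number from compound 2 to compound 1 (0.69 log units; beyond the scatter), and it can be given only as a lower bound because the limit of > 5000000 nM in this assay, at which 1 of the 3 values shown sits, is where the reading of compound 1 stops.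

Compound 3 `Cc1nc([N+](=O)[O-])cn1CC(O)CN1CCN(c2cccc(Cl)c2Cl)CC1` gives 3620000 nM in this assay; this is the higher of the two numbers, and its gap to compound 2 lies beyond the usual scatter. How the core of compound 3 differs from the core of compound 2 is not broken down here.

Compound 4 `CCN1CCN(CC(O)Cn2cc([N+](=O)[O-])nc2C)CC1` stands to compound 3 exactly as compound 1 stands to compound 2: ethyl in place of 2,3-dichlorophenyl on an amine nitrogen in a ring. The place of the change is the same in both pairs, so this is the same change made a second time.

Compound 4 is expected to give 12000000 nM in this assay. The expected step is a 3.3-fold higher number from compound 3 to compound 4 (0.52 log units; beyond the scatter), set beside the measured one an at least 5.0-fold higher number from compound 2 to compound 1 (0.69 log units; beyond the scatter). This expectation rests on compound 3 already standing at 3620000 nM in this assay. It rests also on that same change having carried compound 1 past a limit of the assay, so compound 4 will most likely also be reported only as a limit. The expected range for compound 4 runs from 4000000 nM to 40000000 nM.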

Compound 4, half-maximal inhibitory concentration: > 5000000 nM
Compound 4: only a limit was reported; the forecaster's own chance of this, stated with the estimate: 85%; the middle value is on the limit's open side.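

In this assay, the exchange of 2,3-dichlorophenyl for ethyl on an amine nitrogen in a ring gives an at least 1.3-fold higher number from compound 3 to compound 4 (0.14 log units; that floor lies within the scatter) on the second core, and because compound 4 is reported only as a limit of the assay, this figure is a floor and not a measured size. The two pairs do agree in one respect: on each core, the ethyl compound ends at a limit of the assay, and neither pair shows the exchange giving a lower number. This does not show that the change has the same size on both cores, nor that the step on the second core exceeds the usual scatter: the same change on two cores in this assay, an at least 5.0-fold higher number (0.69 log units; beyond the scatter) from compound 2 to compound 1 and an at least 1.3-fold higher number (0.14 log units; that floor lies within the scatter) from compound 3 to compound 4; the limit leaves it open whether they differ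

The compounds shown leave open how other groups on the same ring nitrogen would read on these two cores, among them an unsubstituted phenyl, a longer chain such as butyl, or a carboxylic acid carried on a short chain. They also leave open how far compound 1 and compound 4 lie past the point where the reading stops: the limit of > 5000000 nM in this assay, at which 2 of the 4 values shown sit.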